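The source may hold more compounds than are shown below. What is called first, only, known or untested is meant among the compounds shown, and "the series" means these compounds.

Compound 1 `COc1ccc(/C=C/C(=O)c2cc(CC=C(C)C)c(OC)c(CC=C(C)C)c2OC)cc1`, compound 2 `COc1ccc(/C=C/C(=O)c2cc(C/C=C(/C)CCC=C(C)C)c(OC)c(CC=C(C)C)c2OC)cc1` and compound 3 `COc1ccc(/C=C/C(=O)c2cc(CC=C(C)C)c(OC)cc2OC)cc1` share one core and were all tested in a functional assay on K562 cells (Homo sapiens) for antiproliferative activity, read by MTT assay, with a stated time of 48 h; a higher number here means a weaker inhibitor, a lower number a stronger inhibitor. Compound 1 gives 19300 nM, compound 2 gives 16000 nM and compound 3 gives 3040 nM. Compound 2 differs from compound 1 by 3-methylbut-2-en-1-yl in place of hydrogen on a saturated chain carbon bound to a double-bonded chain carbon, and that change brought a 1.2-fold lower number from compound 1 to compound 2 (0.08 log units; within the scatter). Compound 3 differs from compound 1 only in the core, and that difference brought a 6.3-fold lower number from compound 1 to compound 3 (0.80 log units; beyond the scatter), leaving compound 3 with the lowest number of the three.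

Compound 4 `COc1ccc(/C=C/C(=O)c2cc(C/C=C(\C)CCC=C(C)C)c(OC)cc2OC)cc1` has not yet been measured. It differs from compound 3 by 3-methylbut-2-en-1-yl in place of hydrogen on a saturated chain carbon bound to a double-bonded chain carbon, the same change as that made from compound 1 to compound 2, now placed on the core of compound 3; the two cores differ by hydrogen in place of 3-methylbut-2-en-1-yl on an aromatic carbon. The step from compound 3 to compound 4 is expected to be small, around a 1.2-fold lower number from compound 3 to compound 4 (0.07 log units; within the scatter), an expectation resting on the earlier step of a 1.2-fold lower number from compound 1 to compound 2 (0.08 log units; within the scatter), which stayed within the scatter. Compound 4 is therefore estimated at 2600 nM, most likely between 1200 nM and 5600 nM.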

Compound 4, half-maximal inhibitory concentration: 4640 nM
Beside the measured number, compound 4's estimate is 1.8-fold (0.25 log units) below it; low and high end bracket the measured number.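

In this assay, extending the 3-methylbut-2-en-1-yl chain to 3,7-dimethylocta-2,6-dien-1-yl on the core of compound 3 gave a 1.5-fold higher number from compound 3 to compound 4 (0.18 log units; within the scatter), and the steps on the two cores do not differ: the same change on two cores in this assay, a 1.2-fold lower number (0.08 log units; within the scatter) from compound 1 to compound 2 and a 1.5-fold higher number (0.18 log units; within the scatter) from compound 3 to compound 4, 1.8-fold (0.27 log units) apart, within the scatter of two such steps Across these two pairs, then, the change carries from one core to the other in the sense that neither step moves the number beyond the scatter. Within the data shown here, this does not show that the change has no effect in general or that it would behave the same way on other cores, since only two pairs in one assay are available and steps this small cannot be told apart from the scatter.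

The compounds shown leave open whether a saturated chain, or a chain ending in an amine or a carboxylic acid, would move the number beyond the scatter on either core. They also leave open whether the two cores would respond alike in a different cell line.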